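Swapping the Imidazolyl Group for an Anilino Group

This account rests on a few compounds, and the source may have more. Where it says the series, first, only, none or still open, it means among the compounds named here.

Of the compounds shown here, three sharing one core have been tested in a functional assay for inhibition of sodium/hydrogen exchanger (Oryctolagus cuniculus); on this read-out lower numbers stand for stronger inhibition and higher numbers for weaker inhibition. Compound 1 `Cc1cc(C)c(S(C)(=O)=O)cc1C(=O)N=C(N)N` gives 11 nM. Compound 2 `Cc1cc(OCc2ccccc2)c(S(C)(=O)=O)cc1C(=O)N=C(N)N` gives 28 nM, and compound 3 `Cc1cc(-n2ccnc2)c(S(C)(=O)=O)cc1C(=O)N=C(N)N` gives 23 nM, the second highest of the three numbers. The steps of a 2.5-fold higher number from compound 1 to compound 2 (0.41 log units; beyond the scatter) and a 2.1-fold higher number from compound 1 to compound 3 (0.32 log units; beyond the scatter) were both modest, whereas the step of a 1.2-fold lower number from compound 2 to compound 3 (0.09 log units; within the scatter) stayed within the usual scatter. Compound 4 `Cc1cc(Nc2ccccc2)c(S(C)(=O)=O)cc1C(=O)N=C(N)N` differs from compound 3 by one change: anilino in place of 1H-imidazol-1-yl on an aromatic carbon. The step of a 1.2-fold lower number from compound 2 to compound 3 (0.09 log units; within the scatter) shows that exchanging one larger substituent for another at this position barely moved the number, so for compound 4 no shift beyond the scatter is expected in this assay, an expected step of a 1.1-fold higher number from compound 3 to compound 4 (0.04 log units; within the scatter). Compound 4 is therefore estimated at 25 nM, within a range of 10 nM to 60 nM.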

Compound 4, half-maximal inhibitory concentration: 21 nM
Compound 4: middle estimate off by 1.2-fold (0.08 log units), on the high side, within the range that was stated.
By their numbers in this assay, from the lowest: compounds 1, 4, 3 and 2 (each within the scatter of the next, the first and the last beyond it).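

Anilino carries a hydrogen-bond donor that 1H-imidazol-1-yl lacks, yet in this assay the steps of a 1.1-fold lower number from compound 3 to compound 4 (0.04 log units; within the scatter) and a 1.3-fold lower number from compound 2 to compound 4 (0.12 log units; within the scatter) are both small, so these three larger groups cannot be told apart here. Anilino is also the only one of them whose step from methyl, a 1.9-fold higher number from compound 1 to compound 4 (0.28 log units; within the scatter), stays within the scatter. No data given here explain these results.

Still open, from the compounds shown here alone, is whether a morpholine or a carboxylic acid at this position would give a similar number. An anilino group with a methyl on its nitrogen would test whether the donor matters.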